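The source may report more compounds than this note shows. Statements on the series, on what has been measured and on what is new or still open speak of the compounds shown alone.

Compound 3 `CN(C)c1ccc(C2CC(c3ccc(-n4ccnc4)cc3)=NN2C(=O)c2ccc(F)cc2)cc1` stands highest of the three compounds measured in a functional assay on HCC1806 cells (Homo sapiens) for inhibition, read by sulforhodamine B assay, tested at 10 uM (a lower number here means less inhibition, a higher number more inhibition at the concentration tested (going by the name of the read-out)), where compound 3 gives 7.1%. Compound 1 `CN(C)c1ccc(C2CC(c3ccc(-n4ccnc4)cc3)=NN2)cc1` gives -20.9%, and compound 2 `CN(C)c1ccc(C2CC(c3ccc(-n4ccnc4)cc3)=NN2C(=O)CCCl)cc1` gives -5.2%. Compound 4 `CN(C)c1ccc(C2CC(c3ccc(-n4ccnc4)cc3)=NN2C(=O)c2cc(Cl)cc(Cl)c2)cc1` differs from compound 3 in one place: 3,5-dichlorophenyl in place of 4-fluorophenyl on a carbonyl carbon. Within the data shown here, the steps that bear on this change are those at the same carbonyl carbon, a number 12.3 percentage points higher from compound 2 to compound 3 (beyond the scatter) and a number 28 percentage points higher from compound 1 to compound 3 (beyond the scatter), both modest; no measured step exchanges one aryl group for another, so the direction of this exchange is uncertain. A small upward or flat step is therefore expected. Compound 4 is estimated at 12%, with a range from -8% to 32%. This estimate corresponds to an expected step of a number 4.9 percentage points higher from compound 3 to compound 4 (within the scatter).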

Compound 4, a percentage reported as inhibition, at one concentration (the size of the read-out at that concentration, not a potency): 44.5%
Compound 4: the middle estimate sits 32.5 percentage points below what was measured, and the stated range ends below it.
By their numbers in this assay, from the lowest: compound 1; then compound 2; then compound 3; then compound 4.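

At this carbonyl carbon, exchanging one aryl group for another is not a neutral change in this assay: 3,5-dichlorophenyl in place of 4-fluorophenyl gives a number 37.4 percentage points higher from compound 3 to compound 4 (beyond the scatter) as the first large step among these compounds. The same group in place of 2-chloroethyl gives a number 49.7 percentage points higher from compound 2 to compound 4 (beyond the scatter) and the full (3,5-dichlorophenyl)carbonyl in place of hydrogen on the amine nitrogen gives a number 65.4 percentage points higher from compound 1 to compound 4 (beyond the scatter) as the widest step here. Nothing available explains the size of these steps. Going by these compounds, it remains open whether a single chlorine, as in 3-chlorophenyl, would do the same, or how 3,5-dimethylphenyl or 3,5-dimethoxyphenyl would behave on this carbonyl carbon.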